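Swapping a ring on the benzimidazole-linked chain

This account rests on a few compounds, and the source may have more. Where it says the series, first, only, none or still open, it means among the compounds named here.

Measured compounds:
- compound 1, `COc1cccc(Cn2c(CN3CCN(C(=O)C4CC4)CC3)nc3ccccc32)c1`: 44.4%
- compound 2, `O=C(C1CC1)N1CCN(Cc2nc3ccccc3n2CC2CC2)CC1`: 21.2%
- compound 3, `O=C(C1CC1)N1CCN(Cc2nc3ccccc3n2CC2CCCC2)CC1`: 44.5%

In an assay on isolated protein for inhibition of aldehyde dehydrogenase 1A1 (Homo sapiens), read by spectrophotometry, tested at 10 uM (a higher number here means more inhibition at the concentration tested (going by the name of the read-out), a lower number less inhibition), compound 3 gives 44.5%, the highest of the three numbers, though compound 1 sits within the scatter of it; only compound 2 lies clearly lower, as the step of a number 23.3 percentage points higher from compound 2 to compound 3 (beyond the scatter) shows.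

Compound 4, `O=C(C1CC1)N1CCN(Cc2nc3ccccc3n2Cc2cccc(Cl)c2)CC1`, has not yet been measured. It differs from compound 3 in one place: 3-chlorophenyl in place of cyclopentyl on a saturated chain carbon bound to an aromatic nitrogen.

Among the compounds with values here, two measured steps bear on this change. The step of a number 23.2 percentage points lower from compound 1 to compound 2 (beyond the scatter) and the step of a number 23.3 percentage points higher from compound 2 to compound 3 (beyond the scatter) together show that a small saturated ring on this carbon costs inhibition, while the larger saturated ring and the methoxy-bearing aromatic ring give numbers within the scatter of each other, as the step of a number 0.1 percentage points higher from compound 1 to compound 3 (within the scatter) confirms. Compound 4 carries an aromatic ring in the same place as compound 1, so no step beyond the scatter is expected in this assay, with the estimated step of a number 1.5 percentage points higher from compound 3 to compound 4 (within the scatter). Compound 4 is therefore expected to give about 46%, in the range 26% to 66%.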

Compound 4, a percentage reported as inhibition, at one concentration (the size of the read-out at that concentration, not a potency): 71.6%
Compound 4: middle estimate off by 25.6 percentage points, on the low side, outside the stated range (above it).
By their numbers in this assay, from the lowest: compound 2; then compounds 1 and 3 (each within the scatter of the next); then compound 4.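

In this assay, an aromatic ring on this saturated chain carbon does not settle the number by itself, since chloro in place of methoxy on that ring gives a number 27.2 percentage points higher from compound 1 to compound 4 (beyond the scatter) and the group carried by the ring therefore matters. Compound 1 and compound 3 had given matching numbers, which made the aromatic and larger saturated rings look interchangeable, but 3-chlorophenyl breaks that match with a number 27.1 percentage points higher from compound 3 to compound 4 (beyond the scatter) and, against the small cyclopropyl, gives a number 50.4 percentage points higher from compound 2 to compound 4 (beyond the scatter) as the widest step in the set. Nothing measured here explains what lies behind these steps.

As far as these compounds go, whether chloro is special remains open: an unsubstituted phenyl, or a fluoro, methyl or trifluoromethyl group on the ring, would help to show this. From the compounds shown here alone, these read-outs at one concentration are also not potencies, so how the steps would translate into potency stays unknown.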